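This account rests on a few compounds, and the source may have more. Where it says the series, first, only, none or still open, it means among the compounds named here.

Working notes on the series.

Three analogues sharing one core have been measured in a functional assay on MCF7 cells (Homo sapiens) for antiproliferative activity, read by MTT assay, with a stated time of 48 h; on this read-out lower numbers stand for stronger inhibition and higher numbers for weaker inhibition. Compound 1 `Cc1ccc(C(=O)Nc2cccc(/C=C/C(=O)c3nc4ccccc4[nH]3)c2)cc1` gives 9690 nM. Compound 2 `COc1ccc(C(=O)Nc2cccc(/C=C/C(=O)c3nc4ccccc4[nH]3)c2)cc1` gives 20100 nM, the change being a 2.1-fold higher number from compound 1 to compound 2 (0.32 log units; beyond the scatter). Compound 3 `O=C(/C=C/c1cccc(NS(=O)(=O)c2cccc(Cl)c2)c1)c1nc2ccccc2[nH]1` gives 4160 nM, the lowest of the three numbers; against it stand a 2.3-fold lower number from compound 1 to compound 3 (0.37 log units; beyond the scatter) and a 4.8-fold lower number from compound 2 to compound 3 (0.68 log units; beyond the scatter), both beyond the scatter but modest.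

Compound 4 `Cc1ccccc1S(=O)(=O)Nc1cccc(/C=C/C(=O)c2nc3ccccc3[nH]2)c1` is the next member, not yet measured. Its difference from compound 3 is 2-methylphenyl in place of 3-chlorophenyl on a sulfonyl sulfur. For the measured compounds named here, no measured step alters the aryl ring attached to the sulfonyl sulfur, so nothing bears on this change directly. Going by the values given here, the only step that swaps a substituent on a pendant aryl ring is the modest one from compound 1 to compound 2, where an exchange on the aryl of the amide moved the number only a little. The steps into compound 3 concern the linker itself, not the aryl, and are set aside.

Compound 4 is therefore expected to sit close to compound 3, with a step of a 1.2-fold higher number from compound 3 to compound 4 (0.08 log units; within the scatter) in this assay, no confident direction. The estimate for compound 4 is 5000 nM, with a range from 2000 nM to 14000 nM.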

Compound 4, half-maximal inhibitory concentration: 4130 nM
For compound 4 the middle estimate is 1.2-fold (0.08 log units) above the measured one; measured number inside the range.
By their numbers in this assay, from the lowest: compounds 4 and 3 (each within the scatter of the next); then compound 1; then compound 2.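

Notes on the sulfonyl aryl. In this assay, for the compounds shown here, the first direct reading at the sulfonyl sulfur shows no separation on exchanging 3-chlorophenyl for 2-methylphenyl (a 1.0-fold lower number from compound 3 to compound 4 (0.00 log units; within the scatter)), so these two aryl groups, which have the same heavy-atom count, cannot be told apart here. Compound 4 also repeats the gaps that compound 3 showed against the two amides (a 2.3-fold lower number from compound 1 to compound 4 (0.37 log units; beyond the scatter) and a 4.9-fold lower number from compound 2 to compound 4 (0.69 log units; beyond the scatter)), so both listed sulfonamides now give lower numbers than both listed amides, with no compound here going against this, though the steps stay modest. No measured evidence is available to explain either the flat step at the sulfonyl sulfur or the gaps to the amides.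

The exchange at the sulfonyl sulfur alters both the substituent and its place on the ring, so the contribution of each remains unresolved, and the flat step covers only these two aryl groups. Going by these compounds, whether an aryl ring carrying an amine or a carboxylic acid, or a longer alkyl chain on the sulfonyl sulfur in place of the aryl, would stay level with compound 3 and compound 4 remains open.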